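This account rests on a few compounds, and the source may have more. Where it says the series, first, only, none or still open, it means among the compounds named here.

Measured compounds:
compound 1 `CC(C)N(Cc1cccc(OCCCCCC(=O)O)c1)C(=O)c1ccc(-c2ccc3cc[nH]c3c2)cc1`. In an ADME assay on BJ cells (Homo sapiens) for cytotoxicity, read by CellTiter-Glo and resazurin assay, with a stated time of 72 h (on this read-out higher numbers stand for an effect only at larger amounts of compound and lower numbers for an effect already at smaller amounts), compound 1 reports a limit and no number, > 26000 nM.
compound 2 `CCOC(=O)CCCCCOc1cccc(CN(C(=O)c2ccc(-c3cccc4ccccc34)cc2)C(C)C)c1`. In this assay compound 2 likewise reports a limit and no number, > 26000 nM.

Compound 2 therefore stands at the top of the range the assay can report; (the limit of > 26000 nM in this assay, at which 2 of the 2 values shown sit), so the two values shown give no order between compound 1 and compound 2, only that neither showed an effect within the tested range. Going by the values given here, no step between measured compounds is available for this series.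

Compound 3 `CCOC(=O)CCCCCOc1cccc(CN(C(=O)c2ccc(-c3cc(F)cc(OC)c3)cc2)C(C)C)c1` is not yet measured. It carries 3-fluoro-5-methoxyphenyl in place of naphthalen-1-yl on an aromatic carbon.

With both measured values sitting at the limit, the step from compound 2 to compound 3 in this assay is expected to be none beyond the scatter, a step that the limit leaves unreadable from compound 2 to compound 3, and most probably compound 3 will again report only a limit. The estimate for compound 3 in this assay is 30000 nM, with a range from 15000 nM to 60000 nM.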

Compound 3, half-maximal effective concentration: > 26000 nM
Compound 3 was reported as a limit; the forecaster's own chance of this, stated with the estimate: 80%; the middle value lies beyond the limit too.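

In this assay compound 3 reports > 26000 nM as a limit only. Compound 2 also reports only a limit there, so no step can be read between compound 2 and compound 3. The compounds shown leave open at what concentration, if any, cytotoxicity would appear.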